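The compounds below may be only part of what the source reports. "The series", "measured", "known", "first", "only" and "open" are said of these compounds alone.

In a functional assay on DU-145 cells (Homo sapiens) for inhibition, read by trypan blue exclusion, with a stated time of 72 h (on this read-out lower numbers stand for stronger inhibition and higher numbers for weaker inhibition), three compounds sharing a core have been measured. Compound 1 `Cn1c(=O)c(S(=O)(=O)c2ccc(F)cc2F)cc2cnc(Nc3ccc4[nH]c(C(=O)O)cc4c3)nc21` gives 10000 nM, compound 2 `Cn1c(=O)c(S(=O)(=O)c2ccc(F)cc2)cc2cnc(Nc3ccc4occc4c3)nc21` gives 5000 nM, and compound 3 `Cn1c(=O)c(S(=O)(=O)c2ccc(F)cc2F)cc2cnc(Nc3ccc4[nH]ncc4c3)nc21` gives 30000 nM. Compound 3 therefore stands highest of the three numbers, and its inhibition is the weakest so far.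

Compound 4 `Cn1c(=O)c(S(=O)(=O)c2ccc(F)cc2)cc2cnc(Nc3ccc4[nH]ncc4c3)nc21` departs from compound 3 in one place: hydrogen in place of fluoro on an aromatic carbon. This is hydrogen in place of fluoro on an aromatic carbon, turning 2,4-difluorophenyl into 4-fluorophenyl.

Within the data shown here, the one measured step, a 3.0-fold higher number from compound 1 to compound 3 (0.48 log units; beyond the scatter), is modest and concerns the group on the nitrogen, so it does not speak directly to this change. Compound 2 carries the same (4-fluorophenyl)sulfonyl group as compound 4, yet it also differs from compound 4 in the group on the nitrogen. Its value therefore cannot isolate the fluoro group. Among the measured compounds shown here, no measured pair shows this change alone.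

In this assay, no step beyond the scatter is expected, with only a slight lean towards a lower number resting on compound 2 at 5000 nM. The expected step is a 1.4-fold lower number from compound 3 to compound 4 (0.13 log units; within the scatter). For compound 4 the estimated value is 22000 nM, with an expected range from 8000 nM to 50000 nM.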

Compound 4, half-maximal inhibitory concentration: 5000 nM
Estimate against measurement, compound 4: 4.4-fold (0.64 log units) above; measured number outside the range, below it.
By their numbers in this assay, from the lowest: compounds 2, 4 and 1 (each within the scatter of the next); then compound 3.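

In this assay, among these compounds, a 6.0-fold lower number from compound 3 to compound 4 (0.78 log units; beyond the scatter) is the first step that isolates this position: with the 1H-indazol-5-yl group held fixed, hydrogen in place of fluoro on the aromatic carbon ortho to a large group moves the number beyond the scatter, so the 2,4-difluorophenyl and 4-fluorophenyl groups are not interchangeable in this pair. The second step, no change at the digits printed from compound 2 to compound 4 (within the scatter), holds the (4-fluorophenyl)sulfonyl group fixed and shows that, with this group in place, 1H-indazol-5-yl and 1-benzofuran-5-yl cannot be told apart in this assay. Nothing available explains why the fluoro group carries this difference in number.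

Whether the same change would give a step of similar size with the 2-carboxy-1H-indol-5-yl group of compound 1 remains open, since the compounds shown test it only with 1H-indazol-5-yl. Going by these compounds, it is also open whether a chloro, methyl or methoxy group on that same aromatic carbon would read like the fluoro group of compound 3 or like the hydrogen of compound 4.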